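Bromo to methoxy on the amide aryl of compound 2

This account rests on a few compounds, and the source may have more. Where it says the series, first, only, none or still open, it means among the compounds named here.

Measured in a functional assay on HCT-116 cells (Homo sapiens) for antiproliferative activity, read by MTT assay, with a stated time of 48 h; on this read-out higher numbers stand for weaker inhibition and lower numbers for stronger inhibition:
compound 1, `O=C(/C=C/c1cccc(NC(=O)c2ccccc2Br)c1)c1nc2ccccc2[nH]1`, 1680 nM
compound 2, `O=C(Nc1cccc(/C=C/C(=O)c2nc3ccccc3[nH]2)c1)c1cccc(Br)c1`, 1560 nM

Compound 2 gives the lowest of the two numbers in this assay, but the step of a 1.1-fold lower number from compound 1 to compound 2 (0.03 log units; within the scatter) is within the scatter, so the two cannot be ordered. Compound 3, `COc1cccc(C(=O)Nc2cccc(/C=C/C(=O)c3nc4ccccc4[nH]3)c2)c1`, differs from compound 2 by methoxy in place of bromo on an aromatic carbon. Among the measured compounds shown here, the only measured step moves bromo on the same ring and says nothing about a bromo-to-methoxy exchange, so no measured step bears on it. Compound 3 is therefore expected near compound 2, the step of a 1.2-fold higher number from compound 2 to compound 3 (0.06 log units; within the scatter) being an open guess. The estimate for compound 3 in this assay is 1800 nM, within 600 nM to 5500 nM.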

Compound 3, half-maximal inhibitory concentration: 3680 nM
For compound 3 the middle estimate is 2.0-fold (0.31 log units) below the measured one; the range from low to high includes it.
By their numbers in this assay, from the lowest: compounds 2 and 1 (each within the scatter of the next); then compound 3.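

In this assay this aromatic carbon responds to which group it carries, a change the bromo shift alone did not reveal: methoxy in place of bromo gives a 2.4-fold higher number from compound 2 to compound 3 (0.37 log units; beyond the scatter). The step of a 2.2-fold higher number from compound 1 to compound 3 (0.34 log units; beyond the scatter) also lies beyond the scatter, so the methoxy compound stands apart from both bromo compounds. Nothing available here accounts for the difference.

Still open, going by these compounds, is whether methoxy in the place held by bromo in compound 1 would read the same. Also open, on these data alone, is how an amine or a carboxylic acid on this aromatic carbon would read.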